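Extending a Fluorophenyl Group to a Fluorophenylethenyl Group

The source may report more compounds than this note shows. Statements on the series, on what has been measured and on what is new or still open speak of the compounds shown alone.

Compound 1 `CC(=O)c1cc(-c2ccc(F)cc2)cc2cc(-c3ccc(F)cc3)[nH]c12` has been measured in a functional assay on HeLa cells (Homo sapiens) for cytotoxicity, read by MTT assay, with a stated time of 2 days, tested at 10 uM (a lower number here means a stronger effect, a higher number a weaker effect of the compound at the concentration tested), where compound 1 gives 47.4%. Among the compounds with values here, only one other number is available: compound 2 `COc1ccc(-c2cc3cc(-c4ccc(F)cc4)cc(C(C)=O)c3[nH]2)cc1` gives 52% in the same test, and the step of a number 4.6 percentage points higher from compound 1 to compound 2 (within the scatter) comes from a methoxy in place of fluoro on an aromatic carbon. Compound 1 therefore stands at essentially the same level as compound 2, the gap being within the scatter. Compound 3 `CC(=O)c1cc(/C=C/c2ccc(F)cc2)cc2cc(-c3ccc(F)cc3)[nH]c12` is not yet measured; it differs from compound 1 in one place: 2-(4-fluorophenyl)ethenyl in place of 4-fluorophenyl on an aromatic carbon. Within the data shown here, no measured step bears on the carbon that carries the 4-fluorophenyl group, so there is no direct precedent, and the single step seen, from compound 1 to compound 2, was within the scatter. Compound 3 is accordingly expected to show a step of a number 0.6 percentage points higher from compound 1 to compound 3 (within the scatter), not beyond the scatter. The estimate for compound 3 is 48%, with a range from 30% to 68%.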

Compound 3, a percentage reported as activity, at one concentration (the size of the read-out at that concentration, not a potency): 41.9%
For compound 3 the middle estimate is 6.1 percentage points above the measured one, within the range that was stated.
By their numbers in this assay, from the lowest: compounds 3, 1 and 2 (each within the scatter of the next, the first and the last beyond it).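

Within the data shown here, on the aromatic carbon meta to the acetyl group, this is the first change that can be read: in this assay, 2-(4-fluorophenyl)ethenyl in place of 4-fluorophenyl gives a number 5.5 percentage points lower from compound 1 to compound 3 (within the scatter). The position therefore takes the larger group, with its double bond outside the aromatic rings, and the read-out at the tested concentration stays level with that of compound 1. Nothing at hand accounts for this result.

As far as these compounds go, whether an amine or a carboxylic acid at this position, or a chain longer than the ethenyl link, would give a step beyond the scatter remains open. From the compounds shown here alone, it is also open whether the same extension would give a similar step on a compound carrying the methoxy group of compound 2.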